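Swapping the dichlorophenyl in a pyrazole chalcone for dimethoxyphenyl

The source may hold more compounds than are shown below. What is called first, only, known or untested is meant among the compounds shown, and "the series" means these compounds.

Three compounds have been measured:
compound 1, `COc1cc(-c2cc(/C=C/C(=O)c3ccc(Cl)c(Cl)c3)[nH]n2)cc(OC)c1OC`, 101%
compound 2, `COc1ccc(-c2cc(/C=C/C(=O)c3ccc(N)cc3)[nH]n2)cc1OC`, 88%
compound 3, `COc1ccc(-c2cc(/C=C/C(=O)c3cc(OC)c(OC)c(OC)c3)[nH]n2)cc1OC`, 78%

All three were tested in a functional assay on ACHN cells (Homo sapiens) for cytotoxicity, read by sulforhodamine B assay, with a stated time of 48 h, tested at 1 uM; a higher number here means a weaker effect of the compound at the concentration tested, a lower number a stronger effect. On these numbers compound 1 stands highest, so it shows the weakest effect of the three; compound 2 lies nearest to it, and compound 3 lies furthest from it, both gaps beyond the usual scatter.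

Compound 4, `COc1ccc(C(=O)/C=C/c2cc(-c3cc(OC)c(OC)c(OC)c3)n[nH]2)cc1OC`, differs from compound 1 in one place: 3,4-dimethoxyphenyl in place of 3,4-dichlorophenyl on a carbonyl carbon. Among the compounds with values here, no measured pair shows this exact change, so its effect can only be guessed. Because compound 3 gives 78% with methoxy groups rather than chlorine on both ends, a moderate lowering is expected, with the step of a number 16 percentage points lower from compound 1 to compound 4 (beyond the scatter) likely just beyond the scatter. Compound 4 is therefore estimated at 85%, within 65% to 100%.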

Compound 4, a percentage reported as activity, at one concentration (the size of the read-out at that concentration, not a potency): 91%
Compound 4: middle estimate off by 6 percentage points, on the low side; low and high end bracket the measured number.
By their numbers in this assay, from the lowest: compounds 3, 2, 4 and 1 (each within the scatter of the next, the first and the last beyond it).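

In this assay, 3,4-dimethoxyphenyl in place of 3,4-dichlorophenyl on a carbonyl carbon gives a step of a number 10 percentage points lower from compound 1 to compound 4 (within the scatter) and so does not separate the two compounds. This first pair differing in one place shows that, at this position, the two groups cannot be told apart by this read-out. Nothing available explains this result.

As far as these compounds go, it remains open whether a carboxylic acid or a nitrile on this phenyl ring would shift the number beyond the scatter.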